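The source may hold more compounds than are shown below. What is called first, only, known or untested is meant among the compounds shown, and "the series" means these compounds.

Measured so far in a functional assay with Mus musculus as the target; a higher number here means a weaker inhibitor, a lower number a stronger inhibitor:
compound 1 `NC1CCCc2onc(O)c21`: 208000 nM
compound 2 `CN(C)C1CCCc2onc(O)c21`: > 500000 nM

Compound 2 gives > 500000 nM, which is a limit of the assay and not a number. Compound 2 therefore stands at the limit of > 500000 nM in this assay, at which 1 of the 2 values shown sits.

The next change leads to compound 3 `Oc1noc2c1C(N1CCCC1)CCC2`, with pyrrolidin-1-yl in place of dimethylamino on a saturated ring carbon.

For the measured compounds named here, only one measured step bears on this change: an at least 2.4-fold higher number from compound 1 to compound 2 (0.38 log units; beyond the scatter). That step put dimethylamino in place of amino on a saturated ring carbon and lies beyond the scatter. Its size is known only as a bound. Going by the values given here, no measured step starts from dimethylamino, so the evidence for this change is indirect. In this assay, no step beyond the scatter is expected, and a drift towards a higher number seems somewhat more likely than one towards a lower number. The estimated step is a step that the limit leaves unreadable from compound 2 to compound 3. For compound 3 the estimate is 600000 nM, with an expected range from 250000 nM to 1500000 nM, and a report as a limit is likely.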

Compound 3, half-maximal inhibitory concentration: > 500000 nM
Compound 3 was reported as a limit; the forecaster's own chance of this, stated with the estimate: 75%; the middle value lies beyond the limit too.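

In this assay compound 3 gives > 500000 nM, which is a limit of the assay and not a number. With pyrrolidin-1-yl in place of amino on the saturated ring carbon, the series shows an at least 2.4-fold higher number from compound 1 to compound 3 (0.38 log units; beyond the scatter), so the shift beyond the scatter seen with dimethylamino also appears with a group carrying a five-membered non-aromatic ring; among the compounds shown, both replacements of amino move the same way and none goes against this. The step between dimethylamino and pyrrolidin-1-yl cannot be read, and the series now runs into the ceiling of the assay: the limit of > 500000 nM in this assay, at which 2 of the 3 values shown sit.

From the compounds shown here alone, whether pyrrolidin-1-yl and dimethylamino differ at all stays open, as does any order among groups that end at this limit. For the compounds shown here, also open is how a methylamino or an acetylamino group on the same saturated ring carbon would stand against compound 1 at 208000 nM, the only value that is a number.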